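This account rests on a few compounds, and the source may have more. Where it says the series, first, only, none or still open, it means among the compounds named here.

Measured so far in an assay on HepG2 cells for agonist activity at nuclear receptor subfamily 1 group I member 3 (Homo sapiens), read by a luciferase reporter, with a stated time of 23 h; on this read-out lower numbers stand for an effect already at smaller amounts and higher numbers for an effect only at larger amounts of compound:
compound 1 `Clc1ccc(CO/N=C/c2c(-c3ccc4ccccc4c3)nc3occn23)c(Cl)c1` — 1500 nM
compound 2 `Clc1ccccc1CO/N=C/c1c(-c2ccc3ccccc3c2)nc2occn12` — 1100 nM

Of the two numbers, compound 2 has the lower one, yet the step of a 1.4-fold lower number from compound 1 to compound 2 (0.13 log units; within the scatter) lies within the scatter, so the two compounds are not separated. Compound 3 `C(=N/OC1Cc2ccccc2C1)\c1c(-c2ccc3ccccc3c2)nc2occn12` is not yet measured; it differs from compound 2 by 2,3-dihydro-1H-inden-2-yl in place of 2-chlorobenzyl on an oxygen. Within the data shown here, no measured step touches the substituent on this oxygen: the only known step concerns a chloro on an aromatic carbon and stayed within the scatter. Without bearing data, the expected step in this assay is a 1.1-fold higher number from compound 2 to compound 3 (0.04 log units; within the scatter), none beyond the scatter. Compound 3 is therefore estimated at 1200 nM, with a range of 400 nM to 4000 nM.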

Compound 3, half-maximal effective concentration: 980 nM
For compound 3 the middle estimate is 1.2-fold (0.09 log units) above the measured one, within the range that was stated.
By their numbers in this assay, from the lowest: compounds 3, 2 and 1 (each within the scatter of the next).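

In this assay the substituent on the oxygen itself now changes, not just a chloro on its aromatic ring: 2,3-dihydro-1H-inden-2-yl in place of 2-chlorobenzyl gives a 1.1-fold lower number from compound 2 to compound 3 (0.05 log units; within the scatter) and in place of 2,4-dichlorobenzyl gives a 1.5-fold lower number from compound 1 to compound 3 (0.18 log units; within the scatter) at this position. Compounds 1, 2 and 3 therefore remain unseparated, even with a five-membered non-aromatic ring in the substituent and no chlorine. No evidence bears on this result.

Open, going by these compounds, is whether an amine, a carboxylic acid or a plain methyl on this oxygen would separate from these compounds. Changes to the shared core also remain open.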